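This account rests on a few compounds, and the source may have more. Where it says the series, first, only, none or still open, it means among the compounds named here.

Going by the values given here, compound 2 `CC1=CC[C@H](C(C)(C)NC(=S)N/N=C/c2ccc(Cl)cc2)CC1` gives 18300 nM in a functional assay on MCF7 cells (Homo sapiens) for inhibition, read by sulforhodamine B assay, with a stated time of 48 h (on this read-out higher numbers stand for weaker inhibition of growth and lower numbers for stronger inhibition of growth), the higher of the two numbers so far; compound 1 `CC1=CC[C@H](C(C)(C)NC(=S)N/N=C/c2ccccc2Cl)CC1` gives 11000 nM, and the step of a 1.7-fold higher number from compound 1 to compound 2 (0.22 log units; within the scatter) stays within the scatter. Compound 3 `CC1=CC[C@H](C(C)(C)NC(=S)N/N=C/c2cccs2)CC1` differs from compound 2 by thiophen-2-yl in place of 4-chlorophenyl on a carbon with a double bond to nitrogen. Among the compounds with values here, the only measured step, from compound 1 to compound 2, exchanges 2-chlorophenyl for 4-chlorophenyl and does not test a five-membered ring in this place, so it bears on compound 3 only loosely. No shift beyond the scatter is expected, and for compound 3 the expected step is a 1.2-fold lower number from compound 2 to compound 3 (0.09 log units; within the scatter). Compound 3 is estimated at 15000 nM, between 5000 nM and 45000 nM.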

Compound 3, concentration for 50% growth inhibition: 4800 nM
For compound 3 the middle estimate is 3.1-fold (0.49 log units) above the measured one, outside the stated range (below it).
By their numbers in this assay, from the lowest: compound 3; then compounds 1 and 2 (each within the scatter of the next).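

In this assay, the place on the carbon with a double bond to nitrogen now gives a shift beyond the scatter: thiophen-2-yl brings a 3.8-fold lower number from compound 2 to compound 3 (0.58 log units; beyond the scatter) and a 2.3-fold lower number from compound 1 to compound 3 (0.36 log units; beyond the scatter), whereas the exchange of 2-chlorophenyl for 4-chlorophenyl stayed within it. On these three compounds, replacing the chlorophenyl group with the five-membered aromatic ring therefore registers at this place. Nothing available accounts for this shift.

From the compounds shown here alone, whether the shift follows the sulfur atom or the five-membered ring remains open. Also open, going by these compounds, is how a furan-2-yl or pyridin-2-yl group would behave at this place.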